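This account rests on a few compounds, and the source may have more. Where it says the series, first, only, none or still open, it means among the compounds named here.

Compound 1 `CCOc1ncc(-c2nc(C(F)(F)F)sc2N2CCN(C(=O)Cn3ccc4cnccc43)[C@H](C)C2)cn1`: 25 nM
Compound 2 `CCOc1ncc(-c2nc(C(F)(F)F)sc2N2CCN(C(=O)Cn3nc(C)cc3C)[C@H](C)C2)cn1`: 60 nM

For the measured compounds named here, in an assay on blood for inhibition of C-X-C chemokine receptor type 3 (Homo sapiens), with a stated time of 30 min (on this read-out lower numbers stand for stronger inhibition and higher numbers for weaker inhibition), compound 2 gives 60 nM, the higher of the two numbers; its only neighbour is compound 1, and the step of a 2.4-fold higher number from compound 1 to compound 2 (0.38 log units; beyond the scatter) runs beyond the scatter. Compound 3 `CCOc1ncc(-c2nc(C(F)(F)F)sc2N2CCN(C(=O)Cn3ccc(C(F)(F)F)n3)[C@H](C)C2)cn1` carries 3-(trifluoromethyl)-1H-pyrazol-1-yl in place of 3,5-dimethyl-1H-pyrazol-1-yl on a saturated chain carbon bound to a carbonyl carbon. Going by the values given here, the single measured step exchanges a different group at this place, so no measured step tells how the trifluoromethyl pyrazole compares with the dimethyl pyrazole. Compound 3 is therefore expected near compound 2, with a 1.2-fold lower number from compound 2 to compound 3 (0.08 log units; within the scatter) as the estimated step. Compound 3 is estimated at 50 nM, within 18 nM to 140 nM.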

Compound 3, half-maximal inhibitory concentration: 90 nM
Compound 3: the middle estimate sits 1.8-fold (0.26 log units) below what was measured; measured number inside the range.
By their numbers in this assay, from the lowest: compound 1; then compounds 2 and 3 (each within the scatter of the next).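

In this assay, the exchange of 3,5-dimethyl-1H-pyrazol-1-yl for 3-(trifluoromethyl)-1H-pyrazol-1-yl on a saturated chain carbon bound to a carbonyl carbon stays within the scatter (a 1.5-fold higher number from compound 2 to compound 3 (0.18 log units; within the scatter)), so this read-out does not separate the two pyrazoles. The group of compound 1 keeps its lead over this second pyrazole as well (a 3.6-fold higher number from compound 1 to compound 3 (0.56 log units; beyond the scatter)). Nothing available explains these numbers. The compounds shown leave open how an amine or a carboxylic acid would read at this place, and how 3-methyl-1H-pyrazol-1-yl would compare.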